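Cytotoxicity of three amine variants and a benzylamino analogue

The source may report more compounds than this note shows. Statements on the series, on what has been measured and on what is new or still open speak of the compounds shown alone.

Compound 1 `Cc1cc(C)cc(Cn2c(=O)cc(NC3CC3)n(Cc3ccccc3)c2=O)c1`: > 100000 nM
Compound 2 `Cc1cc(C)cc(Cn2c(=O)cc(NC3CCCCC3)n(Cc3ccccc3)c2=O)c1`: 74000 nM
Compound 3 `Cc1cc(C)cc(Cn2c(=O)cc(N3CCNCC3)n(Cc3ccccc3)c2=O)c1`: 16000 nM

The three measured compounds share one core and differ only in the group on the aromatic carbon. In an ADME assay on MT4 cells (Homo sapiens) for cytotoxicity, read by MTT assay, with a stated time of 4 days (on this read-out higher numbers stand for lower toxicity in this test and lower numbers for higher toxicity in this test), compound 1 gives > 100000 nM, which is a limit of the assay and not a number. Compound 2 gives 74000 nM in this assay. Compound 3 gives 16000 nM in this assay, the lowest of the two numbers shown. The step of a 4.6-fold lower number from compound 2 to compound 3 (0.67 log units; beyond the scatter) lies beyond the scatter, as does an at least 6.2-fold lower number from compound 1 to compound 3 (0.79 log units; beyond the scatter), whereas an at least 1.3-fold lower number from compound 1 to compound 2 (0.13 log units; that floor lies within the scatter) has a floor that sits within the scatter.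

Compound 4 `Cc1cc(C)cc(Cn2c(=O)cc(NCc3ccccc3)n(Cc3ccccc3)c2=O)c1` has not yet been measured in this assay. Its change from compound 3 is benzylamino in place of piperazin-1-yl on an aromatic carbon. The two steps that bear on it both run toward piperazin-1-yl: a 4.6-fold lower number from compound 2 to compound 3 (0.67 log units; beyond the scatter) and an at least 6.2-fold lower number from compound 1 to compound 3 (0.79 log units; beyond the scatter). Compound 4 moves the other way, from piperazin-1-yl back to a substituted amino group, so the number is expected to rise by a modest step, in the direction of compound 2. Compound 4 is therefore estimated at 70000 nM, with a range from 25000 nM to 150000 nM. This estimate means an expected step of a 4.4-fold higher number from compound 3 to compound 4 (0.64 log units; beyond the scatter).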

Compound 4, half-maximal cytotoxic concentration: > 100000 nM
Compound 4: only a limit was reported; the forecaster's own chance of this, stated with the estimate: 35%; at least 1.4-fold (0.15 log units) between middle value and limit.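

Going by these compounds alone, replacing piperazin-1-yl with benzylamino on the aromatic carbon gives an at least 6.2-fold higher number from compound 3 to compound 4 (0.79 log units; beyond the scatter), which shows that the lower number of compound 3 also stands apart from an amino group carrying an aromatic ring, and not only from the cycloalkylamino groups of the earlier compounds. Against cyclohexylamino the change gives an at least 1.3-fold higher number from compound 2 to compound 4 (0.13 log units; that floor lies within the scatter), and since that floor lies within the scatter, no order can be stated between these two groups, while the step between compound 1 and compound 4 cannot be read, as both values are limits. In this assay compound 4 gives > 100000 nM, which is a limit of the assay and not a number, and the comparison at this position is bounded by it: the limit of > 100000 nM in this assay, at which 2 of the 4 values shown sit.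

On these data alone, how far compound 1 and compound 4 lie beyond that limit remains open, so the amino groups that reach it cannot be ranked. As far as these compounds go, it is also open whether the lower number goes with the piperazin-1-yl ring as a whole or with its ring nitrogen, a question that morpholin-4-yl or 4-methylpiperazin-1-yl on the same aromatic carbon would address.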